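Swapping methyl for fluoro in a small cytotoxic series

The source may hold more compounds than are shown below. What is called first, only, known or untested is meant among the compounds shown, and "the series" means these compounds.

Measured in a functional assay on MCF7 cells (Homo sapiens) for cytotoxicity, read by MTT assay, with a stated time of 24 h; a lower number here means a stronger inhibitor, a higher number a weaker inhibitor:
Compound 1 `CCNc1cc(-c2ccc(NC(=O)Nc3cccc(Cl)c3)cc2C)ccn1`: 4180 nM
Compound 2 `CCNc1cc(-c2ccc(NC(=O)Nc3ccc(OC)cc3)cc2C)ccn1`: 9950 nM
Compound 3 `CCNc1cc(-c2ccc(NC(=O)Nc3ccccc3Cl)cc2C)ccn1`: 8350 nM

Among the compounds with values here, compound 2 stands clear of only one neighbour: the data show a 2.4-fold higher number from compound 1 to compound 2 (0.38 log units; beyond the scatter), a modest step. Its other gap, a 1.2-fold lower number from compound 2 to compound 3 (0.08 log units; within the scatter), is too small to separate the two.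

Compound 4 `CCNc1cc(-c2ccc(NC(=O)Nc3ccc(OC)cc3)cc2F)ccn1` alters compound 2 in one place: fluoro in place of methyl on an aromatic carbon. In words, this is fluoro in place of methyl on an aromatic carbon, ortho to a 2-(ethylamino)pyridin-4-yl group and meta to a large group.

Within the data shown here, no measured step touches that carbon. All three change only the phenyl group on an amide-type nitrogen, and they include a 2.0-fold higher number from compound 1 to compound 3 (0.30 log units; within the scatter) as well as the two above. They show how far numbers in this assay have moved in this small set, but they give no direction for the new change. The best anchor is therefore compound 2 at 9950 nM. The expected step in this assay is a 1.1-fold lower number from compound 2 to compound 4 (0.04 log units; within the scatter), so nothing beyond the scatter is expected. Compound 4 is estimated at 9000 nM, with an expected range from 4000 nM to 20000 nM.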

Compound 4, half-maximal inhibitory concentration: 14100 nM
Beside the measured number, compound 4's estimate is 1.6-fold (0.19 log units) below it; the range from low to high includes it.
By their numbers in this assay, from the lowest: compounds 1, 3, 2 and 4 (each within the scatter of the next, the first and the last beyond it).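

Within the data shown here, replacing methyl with fluoro on this aromatic carbon, ortho to a 2-(ethylamino)pyridin-4-yl group, gives a 1.4-fold higher number from compound 2 to compound 4 (0.15 log units; within the scatter) in this assay and so provides the first reading at this position, as the earlier steps changed only the phenyl group on the amide-type nitrogen. With the 4-methoxyphenyl group in place, this exchange of one heavy atom for another does not separate the two compounds in this assay. Nothing measured here bears on why they sit so close.

This single pair cannot show whether the same exchange would behave alike with the 3-chlorophenyl group of compound 1 or the 2-chlorophenyl group of compound 3. It also leaves open whether an amine, a nitrile or a carboxylic acid on this carbon would shift the number beyond the scatter.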